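Swapping a dimethylphenyl for a dichlorophenyl group

The source may report more compounds than this note shows. Statements on the series, on what has been measured and on what is new or still open speak of the compounds shown alone.

Three measured compounds share one core and differ only in the aromatic group that sits on a saturated chain carbon bound to an aromatic carbon. Compound 1 `COc1ccc(C(=O)CSc2nc(Cc3cccc(O)c3)c(C)c(=O)[nH]2)cc1` carries a 3-hydroxyphenyl group there, and in an ADME assay on MT4 cells (Homo sapiens) for cytotoxicity (on this read-out lower numbers stand for higher toxicity in this test and higher numbers for lower toxicity in this test), compound 1 gives 70000 nM. Compound 2 `COc1ccc(C(=O)CSc2nc(Cc3ccc(Br)cc3)c(C)c(=O)[nH]2)cc1` carries a 4-bromophenyl group; in this assay compound 2 reaches only a limit, > 272000 nM. Compound 3 `COc1ccc(C(=O)CSc2nc(Cc3cc(C)cc(C)c3)c(C)c(=O)[nH]2)cc1` carries a 3,5-dimethylphenyl group; for compound 3 this assay again reports only a limit, > 308000 nM. Compound 3 thus stands at the less toxic end of what was measured, as a limit rather than a number (the limit of > 308000 nM in this assay, at which 1 of the 3 values shown sits). The two readable steps both start from compound 1: an at least 3.8-fold higher number from compound 1 to compound 2 (0.58 log units; beyond the scatter) and an at least 4.4-fold higher number from compound 1 to compound 3 (0.64 log units; beyond the scatter). The step between the two limits, a step that the two limits leave unreadable from compound 2 to compound 3, cannot be sized.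

Compound 4 `COc1ccc(C(=O)CSc2nc(Cc3c(Cl)cccc3Cl)c(C)c(=O)[nH]2)cc1` is not yet measured. It differs from compound 3 by 2,6-dichlorophenyl in place of 3,5-dimethylphenyl on a saturated chain carbon bound to an aromatic carbon. Both readable steps show that replacing the 3-hydroxyphenyl group raised the number beyond the scatter, whether a 4-bromophenyl or a 3,5-dimethylphenyl group entered; the 2,6-dichlorophenyl group of compound 4 likewise carries no hydroxyl. The expected step is therefore an at least 1.2-fold lower number from compound 3 to compound 4 (0.09 log units; that floor lies within the scatter), within the scatter. The estimated value for compound 4 is 250000 nM, in a range from 80000 nM to 400000 nM, quite possibly once more a limit.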

Compound 4, half-maximal cytotoxic concentration: > 278000 nM
Compound 4: only a limit was reported (the forecaster's own chance of this, stated with the estimate: 60%); middle value at least 1.1-fold (0.04 log units) away from the limit.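

In this assay compound 4 also reaches only a limit rather than a number: the limit of > 278000 nM in this assay, at which 1 of the 4 values shown sits. This adds a third group without a hydroxyl, and this time it carries two chlorine atoms in place of the carbon-bearing 3,5-dimethylphenyl group, yet the result matches the earlier ones, with an at least 3.9-fold higher number from compound 1 to compound 4 (0.59 log units; beyond the scatter); among the four compounds, only compound 1 gives a number rather than a limit. The steps among compound 2, compound 3 and compound 4 cannot be read, since each joins two limits, so no order can be stated among the 4-bromophenyl, 3,5-dimethylphenyl and 2,6-dichlorophenyl groups.

Compound 1 is the only compound shown with a hydroxyl, so these four compounds cannot separate what the hydroxyl itself contributes from what belongs to the rest of the 3-hydroxyphenyl group. A plain phenyl group, or a phenyl group carrying an amine or a carboxylic acid, at this place on the shared core would show whether other groups also give a number rather than a limit.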